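The compounds below may be only part of what the source reports. "The series", "measured", "known", "first", "only" and "open" are said of these compounds alone.

Compound 1 `O=[N+]([O-])c1ccc(Oc2ccc(/C=N/NC(=S)Nc3ccc(Br)cc3)cc2)cc1` was measured in a physicochemical assay for lipophilicity, in phosphate buffer, measured as octanol-water partition, with a stated time of 24 h (a lower number here means a more polar compound, a higher number a more lipophilic compound), and gave 5.68. Compound 2 `O=[N+]([O-])c1ccc(Oc2ccc(/C=N/NC(=S)Nc3ccccc3)cc2)cc1` gave 4.95 in this assay. The step of a number 0.73 log units lower from compound 1 to compound 2 (beyond the scatter) corresponds to the change (hydrogen in place of bromo on an aromatic carbon). Compound 3 `Cc1cc(Oc2ccc(/C=N/NC(=S)Nc3ccc(Br)cc3)cc2)ccc1Cl` gave 7.89 in this assay, the highest of the three numbers; its difference from compound 1 is 4-chloro-3-methylphenyl in place of 4-nitrophenyl on an oxygen on an aromatic ring, and the step of a number 2.21 log units higher from compound 1 to compound 3 (beyond the scatter) was the largest seen. Compound 4 `Cc1cc(Oc2ccc(/C=N/NC(=S)Nc3ccccc3)cc2)ccc1Cl` has not yet been measured in this assay. It differs from compound 3 by hydrogen in place of bromo on an aromatic carbon, which is the same change made from compound 1 to compound 2, on the same kind of place, and it shares the core of compound 3. If that change behaves as it did there, the step of a number 0.73 log units lower from compound 3 to compound 4 (beyond the scatter) is expected, resting on the measured step of a number 0.73 log units lower from compound 1 to compound 2 (beyond the scatter). Compound 4 is therefore estimated to give 7.16 in this assay, with a range expected between 6.6 and 7.7, since a single earlier example of the change is the only basis available.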

Compound 4, partition coefficient: 6.03
For compound 4 the middle estimate is 1.13 log units above the measured one; measured number below the stated range.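

In this assay hydrogen in place of bromo on an aromatic carbon gave a number 0.73 log units lower from compound 1 to compound 2 (beyond the scatter) on one core and a number 1.86 log units lower from compound 3 to compound 4 (beyond the scatter) on the other, so the change carried over in direction but not in size. Read from the other side, 4-chloro-3-methylphenyl in place of 4-nitrophenyl gave a number 2.21 log units higher from compound 1 to compound 3 (beyond the scatter) with the bromo present and a number 1.08 log units higher from compound 2 to compound 4 (beyond the scatter) without it, so in these four compounds the two changes do not add independently. Two cores give no rule for the series, and nothing available here speaks to what lies behind the difference in size.

The compounds shown leave open how the step would run on a third core, with a carboxylic acid or an amine on the oxygen-linked ring in place of the chloro and methyl groups. They also leave open whether a longer chain in place of the bromo would follow either of the two steps.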